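From sec-butyl to cyclopentyl on a sulfur

This account rests on a few compounds, and the source may have more. Where it says the series, first, only, none or still open, it means among the compounds named here.

Compound 1 `CCC(CC)O[C@@H]1C=C(C(=O)O)C[C@H](NCc2ccc(C(C)(C)C)cc2)[C@H]1NC(C)=O`: > 200000 nM, a limit
Compound 2 `CCC(CC)O[C@@H]1C=C(C(=O)O)C[C@H](NCc2ccc(Cc3ccccc3)cc2)[C@H]1NC(C)=O`: > 200000 nM, a limit
Compound 3 `CCC(CC)O[C@@H]1C=C(C(=O)O)C[C@H](NCc2ccc(SC(C)CC)cc2)[C@H]1NC(C)=O`: > 200000 nM, a limit

In an ADME assay on cells (Fibroblast, Gallus gallus) for cytotoxicity, read by CCK-8 assay, with a stated time of 48 h (a lower number here means that less compound is tolerated, a higher number that more compound is tolerated), compound 3 gives > 200000 nM, which is a limit and not a number. It shares this position with compound 1 and compound 2, as the limit of > 200000 nM in this assay, at which 3 of the 3 values shown sit, shows.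

Compound 4 `CCC(CC)O[C@@H]1C=C(C(=O)O)C[C@H](NCc2ccc(SC3CCCC3)cc2)[C@H]1NC(C)=O` differs from compound 3 by cyclopentyl in place of sec-butyl on a sulfur; in words, cyclopentyl in place of sec-butyl on a sulfur. Among the compounds with values here, three measured steps bear on this change, all of them replacements on an aromatic carbon. They are a step that the two limits leave unreadable from compound 1 to compound 3, a step that the two limits leave unreadable from compound 2 to compound 3 and a step that the two limits leave unreadable from compound 1 to compound 2. None of them gives a size to carry over, so no step beyond the scatter is expected in this assay, in either direction.

The expected step is a step that the limit leaves unreadable from compound 3 to compound 4. For compound 4 the estimated half-maximal cytotoxic concentration is 250000 nM, with an expected range from 130000 nM to 500000 nM.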

Compound 4, half-maximal cytotoxic concentration: > 200000 nM
Compound 4: a limit, no number (the forecaster's own chance of this, stated with the estimate: 90%); the middle value does not contradict the limit.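

In this assay compound 4 gives > 200000 nM, a limit and not a number. No step linking compound 1, compound 2, compound 3 and compound 4 can be read, as all four share one position: the limit of > 200000 nM in this assay, at which 4 of the 4 values shown sit.

The compounds shown leave open how much of each compound is actually tolerated.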